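Working notes: aryl exchange on the core of compound 3

A few compounds are considered here, and "the series" means these few. Any claim that something is new, unique, unknown or untested is made for them only; others in the source may bear on it.

Measured in a functional assay on HepG2 cells (Homo sapiens) for cytotoxicity, read by sulforhodamine B assay, with a stated time of 48 h; on this read-out higher numbers stand for weaker inhibition and lower numbers for stronger inhibition:
compound 1 `C/C(=N\NC(=O)/C(C#N)=C/N(C)C)c1ccc(NS(=O)(=O)c2ccc(Cl)cc2)cc1` gives 19400 nM
compound 2 `C/C(=N\NC(=O)C(C#N)C(=S)S)c1ccc(NS(=O)(=O)c2ccc(Cl)cc2)cc1` gives 17500 nM
compound 3 `CCOC(=O)c1c(-c2ccc(C)cc2)c(C#N)c(=O)n(/N=C(\C)c2ccc(NS(=O)(=O)c3ccc(Cl)cc3)cc2)c1N` gives 8380 nM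

Compound 3 holds the lowest number of the three; compound 2 stands nearest and compound 1 furthest, both gaps beyond the scatter. Compound 4 `CCOC(=O)c1c(-c2ccccc2Cl)c(C#N)c(=O)n(/N=C(\C)c2ccc(NS(=O)(=O)c3ccc(Cl)cc3)cc2)c1N` differs from compound 3 by 2-chlorophenyl in place of 4-methylphenyl on an aromatic carbon. Among the compounds with values here, the single measured step, a 1.1-fold lower number from compound 1 to compound 2 (0.04 log units; within the scatter), concerns another part of the molecule and lies within the scatter, so it gives no guide to this exchange. Within the data shown here, no measured pair shows one aryl group exchanged for another on this core. The expectation in this assay is therefore no step beyond the scatter, with a wide range for lack of precedent. Compound 4 is estimated at 8400 nM, range 4000 nM to 18000 nM, meaning an expected step of a 1.0-fold higher number from compound 3 to compound 4 (0.00 log units; within the scatter).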

Compound 4, half-maximal inhibitory concentration: 11400 nM
Estimate against measurement, compound 4: 1.4-fold (0.13 log units) below, within the range that was stated.
By their numbers in this assay, from the lowest: compounds 3, 4, 2 and 1 (each within the scatter of the next, the first and the last beyond it).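

In this assay the exchange of 4-methylphenyl for 2-chlorophenyl gives a 1.4-fold higher number from compound 3 to compound 4 (0.13 log units; within the scatter) on the aromatic carbon opposite the ring nitrogen. Within the data shown here, this is the first aryl exchange measured on this core, and this position accepts this one change without a step beyond the scatter. Nothing measured here bears on the reason for this result.

The compounds shown leave open whether 4-chlorophenyl, or a non-aryl group such as an amine or a longer alkyl chain, would keep the number at this level. As far as these compounds go, the effect of replacing the ethoxycarbonyl group with a carboxylic acid on the shared core is also open.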